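The source may report more compounds than this note shows. Statements on the series, on what has been measured and on what is new or still open speak of the compounds shown alone.

Compound 1 `CCn1c(-c2ccc(OCc3c(-c4c(Cl)cccc4Cl)noc3C(C)C)cc2)nc2ccc(C(=O)O)cc21` gives 5760 nM in an assay on HEK-293T cells for antagonist activity at vitamin D3 receptor (Homo sapiens), read by a luciferase reporter, with a stated time of 24 h (on this read-out lower numbers stand for stronger inhibition and higher numbers for weaker inhibition), the highest of the three numbers recorded in this series. Compound 2 `CCC(CC)n1c(-c2ccc(OCc3c(-c4c(Cl)cccc4Cl)noc3C(C)C)cc2Cl)nc2ccc(C(=O)O)cc21` gives 1010 nM in this assay, and compound 3 `CC(C)c1onc(-c2c(Cl)cccc2Cl)c1COc1ccc(-c2nc3ccc(C(=O)O)cc3n2C2CCC2)cc1` gives 1100 nM. Among the compounds with values here, compound 3 differs from compound 1 in one place, cyclobutyl in place of ethyl on an aromatic nitrogen, and the step of a 5.2-fold lower number from compound 1 to compound 3 (0.72 log units; beyond the scatter) is the only single-place change recorded. Within the data shown here, compound 2 differs from compound 1 in more than one place, so no step is drawn between them; its two values can only be set side by side, and they point the same way.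

Compound 4 `CC(C)c1onc(-c2c(Cl)cccc2Cl)c1COc1ccc(-c2nc3ccc(C(=O)O)cc3n2C2CCCCCC2)cc1` is not yet measured. It differs from compound 1 as follows: cycloheptyl in place of ethyl on an aromatic nitrogen. The step that bears on it is a 5.2-fold lower number from compound 1 to compound 3 (0.72 log units; beyond the scatter), where a smaller ring on the aromatic nitrogen replaced ethyl. Among the measured compounds shown here, a seven-membered non-aromatic ring of carbon only is a larger group, and the single relevant step together with the number for compound 2 both lie well below compound 1, so a step in the same direction and of at least similar size is expected, with some room for the larger ring to go further. For compound 4 the expected step is a 7.2-fold lower number from compound 1 to compound 4 (0.86 log units; beyond the scatter). For compound 4 the estimate in this assay is 800 nM, with a range from 250 nM to 2500 nM.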

Compound 4, half-maximal inhibitory concentration: 921 nM
Beside the measured number, compound 4's estimate is 1.2-fold (0.06 log units) below it; the range from low to high includes it.
By their numbers in this assay, from the lowest: compounds 4, 2 and 3 (each within the scatter of the next); then compound 1.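

On the aromatic nitrogen, a second carbocycle in place of ethyl now moves the number the same way in this assay: cycloheptyl gives a 6.3-fold lower number from compound 1 to compound 4 (0.80 log units; beyond the scatter), so the effect seen with cyclobutyl is no longer a single observation, and no ring compound shown here goes against it. The comparison between the two rings is new, and a 1.2-fold lower number from compound 3 to compound 4 (0.08 log units; within the scatter), so cyclobutyl and cycloheptyl cannot be told apart on this read-out, and this position accepts both with no measurable difference. No measured evidence bears on what lies behind either step.

The compounds shown leave open whether a ring is needed at all, since an open chain such as butyl or hexyl on the same nitrogen would separate the presence of a ring from the simple carbon count of the group. They also leave open whether this position accepts heteroatoms, for instance a cycloheptyl ring carrying a hydroxyl or an amine, or a carboxylic acid at the end of a longer chain.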